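Mirror-image pair on a fused bicyclic amine core

The compounds below may be only part of what the source reports. "The series", "measured", "known", "first", "only" and "open" are said of these compounds alone.

Measured compounds:
compound 1, `N[C@H]1CCc2nc(-c3ccncc3)nc(Nc3cccc(F)c3)c2C1`, with 17100 nM in a functional assay on HeLa cells (Homo sapiens) for antiproliferative activity, read by MTT assay, with a stated time of 72 h; a lower number here means a stronger inhibitor, a higher number a weaker inhibitor
compound 2, `CN(C)c1ccc(Nc2nc(-c3ccncc3)nc3c2CC(N)CC3)cc1`, with 38200 nM in this assay

Compound 1 holds the lowest of the two numbers. Its nearest neighbour is compound 2, whose number is higher by a gap that lies beyond the usual scatter, so compound 1 is the stronger of the two measured compounds.

The next compound, compound 3, `N[C@@H]1CCc2nc(-c3ccncc3)nc(Nc3cccc(F)c3)c2C1`, is still to be measured. Its relation to compound 1 is a change in configuration alone: the two compounds have the same atoms and bonds and differ only in configuration as drawn: 1 of 1 stereo elements differ; a stereocentre at a saturated ring carbon is drawn S in compound 1 and R in compound 3. For the measured compounds named here, no pair of measured compounds differs in a single place, so the measured data say nothing about how a change of configuration at this saturated ring carbon moves the number. For this reason compound 3 is expected to stay close to compound 1 in this assay, with no step beyond the scatter in either direction, though a shift either way cannot be excluded. Compound 3 is expected to give 20000 nM, within a range from 6000 nM to 60000 nM. This estimate corresponds to an expected step of a 1.2-fold higher number from compound 1 to compound 3 (0.07 log units; within the scatter).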

Compound 3, half-maximal inhibitory concentration: 21800 nM
Estimate against measurement, compound 3: 1.1-fold (0.04 log units) below, within the range that was stated.
By their numbers in this assay, from the lowest: compounds 1, 3 and 2 (each within the scatter of the next, the first and the last beyond it).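

In this assay, turning the saturated ring carbon from S to R gives a 1.3-fold higher number from compound 1 to compound 3 (0.11 log units; within the scatter). For the compounds shown here, this is the first comparison that isolates a single change, and it shows that the configuration drawn at this stereocentre does not separate the two mirror-image compounds in this assay. The comparison can be read cleanly, as only one feature distinguishes the pair: the fact that compounds 1 and 3 differ only in the configuration as drawn

The compounds shown leave open whether this lack of separation at the stereocentre would persist if the amine on that ring carbon gave way to a hydroxyl group, an acetamide or a longer aminoalkyl chain. They also do not show whether the two configurations would stay as close with a different group in place of the pyridine ring.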